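Cytotoxicity limit across the aryl ether series

The source may hold more compounds than are shown below. What is called first, only, known or untested is meant among the compounds shown, and "the series" means these compounds.

In an ADME assay on CHO cells (Cricetulus griseus) for cytotoxicity, read by MTT assay, with a stated time of 24 h (a lower number here means a stronger inhibitor, a higher number a weaker inhibitor), compound 1 (`CCOS(=O)(=O)/C=C/c1ccc(OCC2=CC[C@@H]3C(C(=O)Nc4ccc(Oc5ccccc5)cc4)=CO[C@@H](OC)[C@H]23)cc1`) gives > 200000 nM, a limit and not a number. Compound 2 (`CCOS(=O)(=O)/C=C/c1ccc(OCC2=CC[C@@H]3C(C(=O)Nc4ccc(Oc5ccc(Br)cc5Cl)cc4)=CO[C@@H](OC)[C@H]23)cc1`) gives > 200000 nM, also a limit and not a number. Compound 2 therefore has no readable position in the series, and the measurements so far come down to the limit of > 200000 nM in this assay, at which 2 of the 2 values shown sit. Within the data shown here, the one measured step is a step that the two limits leave unreadable from compound 1 to compound 2, so it offers no size or direction to carry forward.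

Compound 3 (`CCOS(=O)(=O)/C=C/c1ccc(OCC2=CC[C@@H]3C(C(=O)Nc4ccc(Oc5ccc6ccccc6c5)cc4)=CO[C@@H](OC)[C@H]23)cc1`) differs from compound 2 by naphthalen-2-yl in place of 4-bromo-2-chlorophenyl on an oxygen on an aromatic ring. The change places naphthalen-2-yl in place of 4-bromo-2-chlorophenyl on an oxygen on an aromatic ring.

With only the limit of > 200000 nM in this assay, at which 2 of the 2 values shown sit, to go on, no step beyond the scatter is expected in this assay. The estimated step is a number no higher from compound 2 to compound 3 (the limit leaves the size open). Compound 3 is estimated at 200000 nM, with an expected range of 90000 nM to 400000 nM, and a further limit is the likeliest report.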

Compound 3, half-maximal inhibitory concentration: > 200000 nM
Compound 3 was reported as a limit; the forecaster's own chance of this, stated with the estimate: 80%; the middle value lies on the limit itself.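

Among these compounds, compound 3 is also a limit and not a number, so no step to it from compound 1 or compound 2 can be read, and the series rests on one reading: the limit of > 200000 nM in this assay, at which 3 of the 3 values shown sit.

From the compounds shown here alone, whether any group on that oxygen gives a readable value in this assay remains open.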